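Dimethylating the Urea of a Piperidine Sulfonamide

A few compounds are considered here, and "the series" means these few. Any claim that something is new, unique, unknown or untested is made for them only; others in the source may bear on it.

Compound 1 `Cc1ccccc1C(=O)Nc1ccc(S(=O)(=O)NC2CCN(C(=O)[C@@H]3CCCN3)CC2)c2ccccc12` carries a prolyl amide on its piperidine nitrogen, and in an assay on L1.2 cells for binding affinity to C-C chemokine receptor type 8 (Homo sapiens) (a higher number here means a weaker inhibitor, a lower number a stronger inhibitor), compound 1 gives 0.7 nM; 1 nM (2 entries), a result repeated in the several entries of compound 1 in this assay, 0.7 nM; 1 nM (2 entries). Within the data shown here, compound 2 `Cc1ccccc1C(=O)Nc1ccc(S(=O)(=O)NC2CCN(C(N)=O)CC2)c2ccccc12` swaps that amide for a plain urea; in this assay compound 2 gives 243 nM, which is the only number it shows and places it far weaker than compound 1. Compound 3 `Cc1ccccc1C(=O)Nc1ccc(S(=O)(=O)NC2CCN(C(=O)N(C)C)CC2)c2ccccc12` follows from compound 2 by one change: dimethylamino in place of amino on a carbonyl carbon. Among the measured compounds shown here, no measured pair in this set shares such a change, so the size of the step cannot be read from data. The expectation is a modest move toward stronger binding, of a size at the edge of the usual scatter, with the step of a 2.0-fold lower number from compound 2 to compound 3 (0.31 log units; beyond the scatter) expected for this assay. Compound 3 is accordingly estimated at 120 nM, within a range from 30 nM to 500 nM.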

Compound 3, inhibition constant: 1.6 nM
Beside the measured number, compound 3's estimate is 75-fold (1.88 log units) above it; the whole stated range lies above it.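

Replacing amino with dimethylamino on this carbonyl carbon brings a 150-fold lower number from compound 2 to compound 3 (2.18 log units; beyond the scatter) in this assay, so a small change at this position can have a very large effect on the measured number. Compound 1 and compound 2 alone could suggest that strong binding needs the prolyl amide, yet compound 3 reaches 1.6 nM with no ring in the entering group. This step is also far larger than the spread between repeat results, shown by: the several entries of compound 1 in this assay, 0.7 nM; 1 nM (2 entries)

The compounds shown do not separate the loss of the amino hydrogen-bond donor from the gain of the two carbons, a question that methylamino, with its single methyl, could help to settle. Also open, from the compounds shown here alone, is how diethylamino or a pyrrolidin-1-yl ring would fare on this carbonyl carbon.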